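Methyl in Place of Cyclopropylsulfonyl on the Sulfonamide Aryl

The compounds below may be only part of what the source reports. "The series", "measured", "known", "first", "only" and "open" are said of these compounds alone.

Three measured compounds set the scene in an assay for inhibition of Apoptosis regulator Bcl-2 (Homo sapiens), read by fluorescence polarization, with a stated time of 2 h; a higher number here means a weaker inhibitor, a lower number a stronger inhibitor. Compound 1 `Cc1c(C(=O)NCCCN2CCN(C)CC2)c(-c2cccc(N3CCN(c4ccc(NS(=O)(=O)c5cccc(S(=O)(=O)C6CC6)c5)cc4)CC3)c2)c(-c2ccc(Cl)cc2)n1C` gives 844 nM, the highest number of the three. Compound 2 `CCCCn1c(C)c(C(=O)O)c(-c2cccc(N3CCN(c4ccc(NS(=O)(=O)c5ccc(N[C@H](CCN6CCC(O)CC6)CSc6ccccc6)c(S(=O)(=O)C(F)(F)F)c5)cc4)CC3)c2)c1-c1ccc(Cl)cc1` gives 78.2 nM, and compound 3 `Cc1c(C(=O)O)c(-c2cccc(N3CCN(c4ccc(NS(=O)(=O)c5ccc(N[C@H](CCN6CCCC6)CSc6ccccc6)c(S(=O)(=O)C(F)(F)F)c5)cc4)CC3)c2)c(-c2ccc(Cl)cc2)n1C` gives 8.3 nM, both clearly stronger than compound 1. Compound 4 `Cc1cccc(S(=O)(=O)Nc2ccc(N3CCN(c4cccc(-c5c(C(=O)NCCCN6CCN(C)CC6)c(C)n(C)c5-c5ccc(Cl)cc5)c4)CC3)cc2)c1` differs from compound 1 in one place: methyl in place of cyclopropylsulfonyl on an aromatic carbon, the change reading as 3-(cyclopropylsulfonyl)phenyl to 3-methylphenyl. Among the compounds with values here, no measured pair shows this step, so its size is unknown. Because compound 1 already gives 844 nM, the weakest number shown, and the change trims the group on that ring, compound 4 is expected to give a somewhat higher number, with the step from compound 1 to compound 4 estimated at a 3.0-fold higher number from compound 1 to compound 4 (0.47 log units; beyond the scatter). Compound 4 is thus estimated at 2500 nM, within 800 nM to 8000 nM.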

Compound 4, half-maximal inhibitory concentration: 689 nM
Estimate against measurement, compound 4: 3.6-fold (0.56 log units) above, outside the stated range (below it).
By their numbers in this assay, from the lowest: compound 3; then compound 2; then compounds 4 and 1 (each within the scatter of the next).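

In this assay, replacing cyclopropylsulfonyl with methyl on this aromatic carbon gives a 1.2-fold lower number from compound 1 to compound 4 (0.09 log units; within the scatter), so the two values cannot be told apart. The ring's substituent thus shrinks from six heavy atoms to one and loses both hydrogen-bond acceptors, with no change beyond the scatter in this pair. Nothing shown accounts for this result.

From the compounds shown here alone, whether an amine or a methoxy group at this position would behave the same way remains open. Compound 2 and compound 3 differ from compound 1 in several places, so their lower numbers cannot be assigned to any single change.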